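This account rests on a few compounds, and the source may have more. Where it says the series, first, only, none or still open, it means among the compounds named here.

Working notes on the series in a physicochemical assay for lipophilicity; a lower number here means a more polar compound, a higher number a more lipophilic compound.

Compound 1 `O=c1ccn(CCN2CCCCC2)c(CO)c1O` gives 0.019. Compound 3 `CC(O)c1c(O)c(=O)ccn1CCN1CCCCC1` gives 0.242; the step of a number 0.22 log units higher from compound 1 to compound 3 (within the scatter) is the change (methyl in place of hydrogen on a saturated chain carbon bound to an aromatic carbon and an oxygen on a saturated carbon). Compound 2 `Cc1c(O)c(=O)ccn1CCN(C)C` gives -0.657, the lowest of the three numbers, the nearest being compound 1 at a gap beyond the scatter. The difference between the core of compound 2 and the core of compound 1 is not broken down here.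

Compound 4 `CCc1c(O)c(=O)ccn1CCN(C)C` is not yet measured. It differs from compound 2 by methyl in place of hydrogen on a saturated chain carbon bound to an aromatic carbon, the same kind of change as from compound 1 to compound 3, though there the place also carried an oxygen on a saturated carbon. A step of a number 0.31 log units higher from compound 2 to compound 4 (beyond the scatter) is expected from compound 2 to compound 4, resting on the size of a number 0.22 log units higher from compound 1 to compound 3 (within the scatter). Compound 4 is thus estimated at -0.35, between -0.75 and 0.05.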

Compound 4, partition coefficient: -0.114
Estimate against measurement, compound 4: 0.24 log units below; measured number inside the range.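

In this assay, methyl in place of hydrogen on a saturated chain carbon bound to an aromatic carbon gives a number 0.54 log units higher from compound 2 to compound 4 (beyond the scatter), while the same kind of change at a place that also carries an oxygen on a saturated carbon gives a number 0.22 log units higher from compound 1 to compound 3 (within the scatter). The change therefore reads beyond the scatter on the core of compound 2 only, and with a single pair per core, the difference in core cannot be separated from the presence of that oxygen, so carry-over between cores is neither shown nor excluded. Nothing available accounts for the size of either step.

The compounds shown leave open how a longer chain, such as propyl, or an amine would read at this place. They also leave open whether the core of compound 1 would give a similar step without the oxygen.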